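Swapping tert-butyl for isopropyl: an expected small step

The compounds below may be only part of what the source reports. "The series", "measured", "known", "first", "only" and "open" are said of these compounds alone.

- compound 1 `CC(=O)Nc1cnc2[nH]c(=O)n([C@H]3CC[C@H](C(C)(C)C)CC3)c(=O)c2c1` gives 67000 nM
- compound 2 `CC(=O)Nc1cnc2[nH]c(=O)n([C@H]3CC[C@@H](C(C)(C)C)CC3)c(=O)c2c1` gives 15000 nM

In an ADME assay on L6 cells (Rattus norvegicus) for cytotoxicity, read by resazurin assay, with a stated time of 70 h (on this read-out lower numbers stand for an effect already at smaller amounts and higher numbers for an effect only at larger amounts of compound), compound 1 gives 67000 nM, the higher of the two measured numbers. The next compound to be tested is compound 3 `CC(=O)Nc1cnc2[nH]c(=O)n([C@H]3CC[C@H](C(C)C)CC3)c(=O)c2c1`. It departs from compound 1 by one small change, (hydrogen in place of methyl on a saturated chain carbon bound to two saturated chain carbons and a saturated ring carbon), which turns tert-butyl into isopropyl. Among the measured compounds shown here, only one measured step is available, a 4.5-fold lower number from compound 1 to compound 2 (0.65 log units; beyond the scatter), and it bears on this change only indirectly, since it reflects (the fact that compounds 1 and 2 differ only in the configuration as drawn). For the measured compounds named here, no measured step removes a methyl, so that step gives no direction and only shows that this assay can respond to a modest structural difference. No shift beyond the usual scatter is therefore expected, and the estimated step is a 1.1-fold lower number from compound 1 to compound 3 (0.05 log units; within the scatter). For compound 3 the expected value is 60000 nM, with an estimated range from 25000 nM to 120000 nM.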

Compound 3, half-maximal effective concentration: 32000 nM
Beside the measured number, compound 3's estimate is 1.9-fold (0.27 log units) above it; the range from low to high includes it.
By their numbers in this assay, from the lowest: compound 2; then compound 3; then compound 1.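

Taking one methyl off the tert-butyl group gives a 2.1-fold lower number from compound 1 to compound 3 (0.32 log units; beyond the scatter), so in this assay the number depends on the make-up of this group and not only on its configuration as drawn. Among the compounds shown here, the step is modest, but it gives this change a direction for the first time: with hydrogen in place of methyl, the number falls rather than rises. Nothing in the available evidence explains why this single change moves the number.

As far as these compounds go, whether the number would keep falling with a still smaller group such as ethyl or methyl, or move differently with an amine or a carboxylic acid in this place, remains open. From the compounds shown here alone, it is also open whether isopropyl would give a similar step in the configuration drawn for compound 2.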